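The source may hold more compounds than are shown below. What is called first, only, known or untested is meant among the compounds shown, and "the series" means these compounds.

Compound 1, `CC(C)(C)CCOc1cccc(O)c1C(=O)/C=C/c1ccc(C(=O)O)cc1`, is one of three chalcones measured in a functional assay on NUGC-3 cells (Homo sapiens) for antiproliferative activity, read by sulforhodamine B assay (on this read-out lower numbers stand for stronger inhibition of growth and higher numbers for weaker inhibition of growth), where compound 1 gives 5440 nM. Its companions share the core but differ in the alkyl ether and in the group on the distal ring: compound 2, `CC(C)CCCOc1cccc(O)c1C(=O)/C=C/c1ccc(O)cc1`, gives 3520 nM in this assay, and compound 3, `CC(C)CCOc1cccc(O)c1C(=O)/C=C/c1ccc(O)cc1`, gives 12400 nM. Going by the values given here, the single step that can be read cleanly among them runs along the ether chain: a 3.5-fold higher number from compound 2 to compound 3 (0.55 log units; beyond the scatter). On these numbers compound 1 stands second highest of the three; it lies within the scatter of compound 2 and beyond the scatter of compound 3.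

Compound 4, `CC(C)(C)CCOc1cccc(O)c1C(=O)/C=C/c1ccc(S(N)(=O)=O)cc1`, differs from compound 1 in one place: sulfamoyl in place of carboxy on an aromatic carbon. Among the compounds with values here, no measured step touches the group on that aromatic carbon, so the one step recorded, between compound 2 and compound 3, does not bear on the change directly, and nothing in the set indicates the direction. The author therefore expects the growth inhibition of compound 4 to stay near that of compound 1, with a step of a 1.2-fold lower number from compound 1 to compound 4 (0.08 log units; within the scatter) that need not exceed the scatter. Compound 4 is estimated at 4500 nM, within a range of 1500 nM to 14000 nM.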

Compound 4, concentration for 50% growth inhibition: 1170 nM
Compound 4: the middle estimate sits 3.8-fold (0.59 log units) above what was measured; measured number below the stated range.
By their numbers in this assay, from the lowest: compound 4; then compounds 2 and 1 (each within the scatter of the next); then compound 3.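

In this assay, the exchange of carboxy for sulfamoyl on this aromatic carbon gives a 4.6-fold lower number from compound 1 to compound 4 (0.67 log units; beyond the scatter). Going by these compounds alone, the group held at this carbon therefore moves the read-out beyond the scatter, something the earlier compounds could not show, as their one readable step lay along the ether chain. With that chain the same in both compounds, the change is confined to this one place: sulfamoyl brings 4 heavy atoms and 2 hydrogen-bond acceptors where carboxy has 3 heavy atoms and 1 hydrogen-bond acceptor, with 1 hydrogen-bond donor and no net charge on either side, and no measurement shown here explains the step.

What the compounds shown leave open is whether a methyl ester, a primary amide or an N-methylsulfamoyl group on this aromatic carbon would follow sulfamoyl or carboxy. From the compounds shown here alone, it is also open whether the same exchange would give a step of similar size on the ether chain of compound 2 or of compound 3, as each of those carries a hydroxy group at this carbon instead.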